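The compounds below may be only part of what the source reports. "The series", "measured", "known", "first", "only" and "open" are said of these compounds alone.

Of the compounds shown here, three have been tested in a functional assay on HEK293 cells for antagonist activity at Orexin receptor type 2 (Homo sapiens), read by FLIPR and calcium flux; a lower number here means a less potent compound, a higher number a more potent compound, by a factor of ten per unit of this negative logarithm. Compound 1, `Cc1ccc(-c2ncccn2)c(C(=O)N2CCC3(CC3)C[C@H]2CNc2ccc(Cl)cn2)c1`, gives in this assay a value of < 5, which is a limit of the measurement and not a number. Compound 2, `Cc1ccnc(NC[C@@H]2CC3(CC3)CN2C(=O)c2nc(C)sc2-c2ccccc2)n1`, gives in this assay a value of 7. Compound 3, `O=C(c1cc(Cl)ccc1-c1ncccn1)N1CC2(CC2)C[C@H]1CNc1ccc(C(F)(F)F)cn1`, gives in this assay a value of 7.2. The numbers of compound 2 and compound 3 lie within the usual scatter of each other, so neither can be set apart from the other on these data; the remaining value, that of compound 1, is the limit of < 5 in this assay, at which 1 of the 3 values shown sits.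

Compound 4, `Cc1nc(C(=O)N2CC3(CC3)C[C@H]2CNc2ncc(Cl)cn2)c(-c2ccccc2)s1`, has not yet been measured. Among the measured compounds shown here, it differs from compound 2 in one place: 5-chloropyrimidin-2-yl in place of 4-methylpyrimidin-2-yl on an amine nitrogen No measured pair of compounds shows this change on its own, so there is no direct guide to how large a step it brings. Since the change swaps one group for another of the same kind at the same place, the expected step, a number 0.20 log units higher from compound 2 to compound 4 (within the scatter), is small and would fall within the scatter. Compound 4 is therefore estimated to give 7.2 in this assay, with a likely range from 6.3 to 8.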

Compound 4, negative logarithm of the antagonist equilibrium constant: 6.8
The estimate for compound 4 lay 0.40 log units above the measured number; low and high end bracket the measured number.
By their numbers in this assay, from the lowest: compounds 4, 2 and 3 (each within the scatter of the next, the first and the last beyond it). At a limit, below all of these: compound 1.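

Holding the rest of the molecule fixed, this assay gives the first direct reading at this place, and 5-chloropyrimidin-2-yl in place of 4-methylpyrimidin-2-yl on the amine nitrogen gives a number 0.20 log units lower from compound 2 to compound 4 (within the scatter). On these data, compound 2 and compound 4 cannot be set apart, so this place accepts either group, at least on this core, with no measurable effect on antagonist potency. Nothing measured here explains why the two groups read alike.

The swap removes a methyl and brings in a chlorine at a different ring position in a single step, so the contribution of each remains unseparated, and the unsubstituted pyrimidin-2-yl group would be needed to tell them apart. From the compounds shown here alone, it also remains open whether this tolerance extends to quite different substituents on the pyrimidine, such as a methoxy group, an amine or a carboxylic acid, or to the same exchange on a core carrying a different amide partner.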